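The compounds below may be only part of what the source reports. "The series", "measured", "known", "first", "only" and "open" are said of these compounds alone.

In a functional assay on CCRF-CEM cells (Homo sapiens) for cytotoxicity (a lower number here means a stronger inhibitor, a higher number a weaker inhibitor), compound 1 `Nc1ccn([C@H]2C=C(F)[C@@H](CO)O2)c(=O)n1` gives > 100000 nM, which is a limit and not a number. Compound 2 `Nc1nc(=O)n([C@H]2C=C(F)[C@@H](CO)O2)cc1F` gives > 100000 nM, also a limit. Compound 3 `Nc1ccn([C@@H]2C=C(F)[C@H](CO)O2)c(=O)n1` gives > 100000 nM, again a limit, and so it stands with the others at the limit of > 100000 nM in this assay, at which 3 of the 3 values shown sit. Compound 4 `Nc1nc(=O)n([C@@H]2C=C(F)[C@H](CO)O2)cc1F` derives from compound 3 by one change, fluoro in place of hydrogen on an aromatic carbon. The same change appears as a step that the two limits leave unreadable from compound 1 to compound 2. Mirror inversion appears as a step that the two limits leave unreadable from compound 1 to compound 3, given (the fact that compounds 1 and 3 differ only in the configuration as drawn). Neither step has a readable size, so no clear shift in either direction is expected. The expected change is a number no higher from compound 3 to compound 4 (the limit leaves the size open). Compound 4 is estimated at 100000 nM, with an expected range from 30000 nM to 100000 nM.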

Compound 4, half-maximal inhibitory concentration: > 100000 nM
Compound 4 was reported as a limit; the forecaster's own chance of this, stated with the estimate: 80%; the middle value lies on the limit itself.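

Compound 4 is reported only as a limit, as are compound 2 and compound 3, so neither the fluoro step from compound 3 nor the mirror-image step from compound 2 can be read. The compounds shown leave open whether fluoro or configuration changes anything in this assay.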